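The compounds below may be only part of what the source reports. "The series", "measured", "known", "first", "only" and "open" are said of these compounds alone.

Compound 1 `COc1ccc(-c2cnc(NC(=O)C3CCCC3)n2C)cc1`. In a toxicity assay on THP-1 cells (Homo sapiens) for inhibition (a higher number here means that more compound is tolerated, a lower number that less compound is tolerated), compound 1 gives > 100000 nM, which is a limit of the assay and not a number.
Compound 2 `COc1ccc(-c2cnc(NC(=O)c3ccccc3)n2C)cc1`. In this assay compound 2 gives > 100000 nM, again a limit rather than a number.
Compound 3 `COc1ccc(-c2cnc(NC(=O)c3ccc(O)cc3)n2C)cc1`. In this assay compound 3 gives > 100000 nM, also a limit and not a number.

Compound 3 therefore stands where every value here stands: at the limit of > 100000 nM in this assay, at which 3 of the 3 values shown sit. None of the three measured steps can be read, since each runs between two limits: a step that the two limits leave unreadable from compound 1 to compound 2, a step that the two limits leave unreadable from compound 1 to compound 3 and a step that the two limits leave unreadable from compound 2 to compound 3 all have no readable size.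

Compound 4 `COc1ccc(-c2cnc(NC(=O)C3CCNCC3)n2C)cc1` is not yet measured. It differs from compound 3 in one place: piperidin-4-yl in place of 4-hydroxyphenyl on a carbonyl carbon.

Among the measured compounds shown here, no measured step bears on this change with a readable size, so no direction or size can be derived from them. The expectation for this assay rests only on the fact that every measured compound sits at the same limit, and the step from compound 3 to compound 4 is expected to be a number no higher from compound 3 to compound 4 (the limit leaves the size open), nothing beyond the scatter. Compound 4 is therefore estimated at 100000 nM in this assay, with a range from 30000 nM to 300000 nM, and most likely another limit.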

Compound 4, half-maximal cytotoxic concentration: > 100000 nM
Compound 4: a limit, no number; the forecaster's own chance of this, stated with the estimate: 85%; the middle value lies on the limit itself.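

Compound 4, like compounds 1, 2 and 3, gives only a limit and not a number, so no step among these four compounds can be read: the limit of > 100000 nM in this assay, at which 4 of the 4 values shown sit.

How much of any of these compounds this assay would tolerate beyond that limit, and whether the acyl groups differ there, stays open.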